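Sulfonamide ring swaps on a coumarin enaminone aromatase series

The source may hold more compounds than are shown below. What is called first, only, known or untested is meant among the compounds shown, and "the series" means these compounds.

Measured compounds:
- Compound 1, `O=C(/C=C\Nc1ccc(S(=O)(=O)Nc2ccccn2)cc1)c1cc2ccccc2oc1=O`: 12500 nM
- Compound 2, `Cc1ccnc(NS(=O)(=O)c2ccc(N/C=C\C(=O)c3cc4ccccc4oc3=O)cc2)n1`: 9520 nM

Both compounds were tested in an assay on T47D cells for inhibition of Aromatase (Homo sapiens), with a stated time of 24 h; on this read-out higher numbers stand for weaker inhibition and lower numbers for stronger inhibition. Compound 1 gives 12500 nM, and compound 2 gives 9520 nM. Among the measured compounds shown here, the only measured step, a 1.3-fold lower number from compound 1 to compound 2 (0.12 log units; within the scatter), replaces the pyridin-2-yl group on the sulfonamide nitrogen with a 4-methylpyrimidin-2-yl group, and the two numbers lie within the scatter of one another, so compound 2 stands level with compound 1 rather than apart from it.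

Compound 3, `COc1cnc(NS(=O)(=O)c2ccc(N/C=C\C(=O)c3cc4ccccc4oc3=O)cc2)nc1`, has not yet been measured. It differs from compound 2 in one place: 5-methoxypyrimidin-2-yl in place of 4-methylpyrimidin-2-yl on a sulfonamide nitrogen. For the measured compounds named here, the one known step bears on this change only loosely, since it also altered the ring on the sulfonamide nitrogen and produced no movement beyond the scatter. Going by the values given here, no measured pair tells what a methoxy group in place of a methyl group on that ring does here. With so little to go on, the step from compound 2 to compound 3 is expected to stay within the scatter, a 1.0-fold lower number from compound 2 to compound 3 (0.00 log units; within the scatter). For compound 3 the expected value in this assay is 9500 nM, with a range from 4000 nM to 25000 nM.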

Compound 3, half-maximal inhibitory concentration: 6070 nM
Compound 3: middle estimate off by 1.6-fold (0.19 log units), on the high side; measured number inside the range.
By their numbers in this assay, from the lowest: compounds 3, 2 and 1 (each within the scatter of the next, the first and the last beyond it).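

Changing the ring on the sulfonamide nitrogen once more, a 1.6-fold lower number from compound 2 to compound 3 (0.20 log units; within the scatter) stays within the scatter in this assay and so does not separate the 5-methoxypyrimidin-2-yl group from the 4-methylpyrimidin-2-yl group. Among the compounds shown here, measured against the pyridin-2-yl group, however, a 2.1-fold lower number from compound 1 to compound 3 (0.31 log units; beyond the scatter) is the only step here that passes beyond the scatter, which shows that the group on this nitrogen can move the number, though only modestly. Nothing measured on these compounds accounts for that shift.

As far as these compounds go, whether the methoxy group or the ring nitrogens carry this modest step remains open, and a plain pyrimidin-2-yl ring on the sulfonamide nitrogen would help to separate the two. Equally open, from the compounds shown here alone, is what an acetyl group or a phenyl ring would do on that nitrogen, and what an amine or a carboxylic acid would do as a substituent on the ring.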